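This account rests on a few compounds, and the source may have more. Where it says the series, first, only, none or still open, it means among the compounds named here.

Compounds measured so far:
- compound 1, `CCCCCCCCCCCC(=O)OC[C@H](CSC[C@@H](N)C(=O)N[C@H](C)CO)OC(=O)CCCCCCCCCCC`, 22200 nM
- compound 2, `CCCCCCCCCCCC(=O)OC[C@H](CSC[C@@H](N)C(=O)NCCCCCCO)OC(=O)CCCCCCCCCCC`, 33 nM
- compound 3, `CCCCCCCCCCCC(=O)OC[C@H](CSC[C@@H](N)C(=O)NCCCS(=O)(=O)O)OC(=O)CCCCCCCCCCC`, 5560 nM

All three share one core and differ only in the group carried on the amide-type nitrogen. In an assay on HEK293 cells for agonist activity at Toll-like receptor 2 (Homo sapiens) (on this read-out higher numbers stand for an effect only at larger amounts of compound and lower numbers for an effect already at smaller amounts), compound 3 stands second highest of the three: compound 1 sits above it, with a 4.0-fold lower number from compound 1 to compound 3 (0.60 log units; beyond the scatter), while compound 2 sits far below, with a 170-fold higher number from compound 2 to compound 3 (2.23 log units; beyond the scatter).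

Compound 4, `CCCCCCCCCCCC(=O)OC[C@H](CSC[C@@H](N)C(=O)NC(CC)COC)OC(=O)CCCCCCCCCCC`, has not yet been measured. It differs from compound 3 by 1-(methoxymethyl)propyl in place of 3-sulfopropyl on an amide-type nitrogen.

Within the data shown here, two measured steps bear on this. The step from compound 2 to compound 3 shows that placing a sulfo group on the chain goes with a much higher number, so taking it away again could lower the number. Yet compound 1, whose group is also branched at the carbon next to the nitrogen, gives the highest number of all, and the step from compound 1 to compound 2 was a 670-fold lower number from compound 1 to compound 2 (2.83 log units; beyond the scatter). The expected outcome is therefore uncertain, and for compound 4 the step is estimated at a 2.2-fold lower number from compound 3 to compound 4 (0.35 log units; beyond the scatter). For compound 4 in this assay the estimate is 2500 nM, within a range from 250 nM to 25000 nM.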

Compound 4, half-maximal effective concentration: 71.8 nM
Compound 4: the middle estimate sits 35-fold (1.54 log units) above what was measured, and the stated range ends above it.
By their numbers in this assay, from the lowest: compound 2; then compound 4; then compound 3; then compound 1.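

At the amide-type nitrogen, a branched group does not by itself bring a high number in this assay: with 1-(methoxymethyl)propyl there is a 310-fold lower number from compound 1 to compound 4 (2.49 log units; beyond the scatter), and in place of 3-sulfopropyl there is a 77-fold lower number from compound 3 to compound 4 (1.89 log units; beyond the scatter). The gap to the unbranched 6-hydroxyhexyl group narrows to a 2.2-fold higher number from compound 2 to compound 4 (0.34 log units; beyond the scatter), so a group with no hydrogen-bond donor comes close to the lowest number in the set, while compound 1 remains the branched example that stays high. Nothing measured here explains why these groups differ so much.

As far as these compounds go, compound 1 and compound 4 differ in both the methyl ether and the length of the branch, so it remains open which of the two goes with the lower number. A 1-(hydroxymethyl)propyl group would separate them, and a carboxylic acid at the end of the propyl chain would test whether the high number of compound 3 is particular to the sulfo group.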